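From 2-methylphenyl to 4-methylphenyl on the same core

The source may report more compounds than this note shows. Statements on the series, on what has been measured and on what is new or still open speak of the compounds shown alone.

compound 1 (`O=c1[nH]cc(S(=O)(=O)Nc2cccc(-c3cn(-c4ccccc4)nn3)c2)c(=O)[nH]1`): 11200 nM
compound 2 (`Cc1ccccc1-n1cc(-c2cccc(NS(=O)(=O)c3c[nH]c(=O)[nH]c3=O)c2)nn1`): 9570 nM

Going by the values given here, in a functional assay on HepG2 cells (Homo sapiens) for antiproliferative activity, read by MTT assay, with a stated time of 24 h (a higher number here means a weaker inhibitor, a lower number a stronger inhibitor), compound 2 gives 9570 nM and so lies within the usual scatter of compound 1, the only other measured compound. Compound 3 (`Cc1ccc(-n2cc(-c3cccc(NS(=O)(=O)c4c[nH]c(=O)[nH]c4=O)c3)nn2)cc1`) keeps the shared core and differs in one group (4-methylphenyl in place of 2-methylphenyl on an aromatic nitrogen): 4-methylphenyl in place of 2-methylphenyl on an aromatic nitrogen. The two compounds have the same atoms, joined differently. Among the compounds with values here, the only measured step that bears on this is methyl in place of hydrogen on an aromatic carbon (a 1.2-fold lower number from compound 1 to compound 2 (0.07 log units; within the scatter)), and it stays within the scatter. Within the data shown here, no measured compound carries the 4-methylphenyl group, so the evidence is thin. A change beyond the scatter is not expected in this assay for compound 3. The estimated step (a 1.0-fold lower number from compound 2 to compound 3 (0.00 log units; within the scatter)) is correspondingly small. For compound 3 the expected value is 9500 nM (estimated range 5000 nM to 18000 nM).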

Compound 3, half-maximal inhibitory concentration: > 20000 nM
Compound 3: a limit, no number; the forecaster's own chance of this, stated with the estimate: 5%; at least 2.1-fold (0.32 log units) between middle value and limit.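

In this assay compound 3 gives a limit, not a number: the limit of > 20000 nM in this assay, at which 1 of the 3 values shown sits.

Moving the methyl on the aromatic nitrogen's ring, from 2-methylphenyl to 4-methylphenyl, uses the same atoms yet gives an at least 2.0-fold higher number from compound 2 to compound 3 (0.32 log units; beyond the scatter), so where the methyl sits matters here, something that adding it in a 1.2-fold lower number from compound 1 to compound 2 (0.07 log units; within the scatter) did not reveal. Set against the unsubstituted phenyl group, the change reads an at least 1.7-fold higher number from compound 1 to compound 3 (0.25 log units; that floor lies within the scatter), and this floor alone does not separate the two compounds.

From the compounds shown here alone, how weak compound 3 really is stays open, since only a floor is known for both of its steps. Also open, going by these compounds, is whether the loss follows from the methyl alone or would recur with a chlorine, a methoxy group or a carboxylic acid in its place on the same ring.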